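Methoxycarbonyl removal in a cytotoxicity screen: compound 4 pending

The source may report more compounds than this note shows. Statements on the series, on what has been measured and on what is new or still open speak of the compounds shown alone.

Measured so far, all in an ADME assay on J774 cells (Mus musculus) for cytotoxicity; a higher number here means that more compound is needed for the effect, a lower number that less compound is needed:
- compound 1 `COC(=O)c1c[nH]c2cc(OCCOc3ccccc3)ccc2c1=O`; compound 1 gives > 20000 nM, a limit of the assay, not a number.
- compound 2 `CCCCc1ccc2[nH]cc(C(=O)OC)c(=O)c2c1`; compound 2 gives > 20000 nM, likewise a limit.
- compound 3 `O=c1cc[nH]c2cc(OCCOc3ccccc3)ccc12`; compound 3 gives > 20000 nM, likewise a limit.

Within the data shown here, every value so far sits at the limit of > 20000 nM in this assay, at which 3 of the 3 values shown sit. Compound 3 is obtained from compound 1 by hydrogen in place of methoxycarbonyl on an aromatic carbon. The step that the two limits leave unreadable from compound 1 to compound 3 is therefore unreadable in this assay, since both ends are limits. How the core of compound 2 differs from the core of compound 1 is not broken down here.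

Compound 4 `CCCCc1ccc2[nH]ccc(=O)c2c1` has not yet been measured in this assay. It is obtained from compound 2 by hydrogen in place of methoxycarbonyl on an aromatic carbon, the same change that leads from compound 1 to compound 3, with the place described in identical terms. Because compound 1 and compound 3 both sit at the limit of > 20000 nM in this assay, at which 3 of the 3 values shown sit, that precedent gives no readable size for the step.

Expectation: compound 4 is expected to remain at the limit in this assay, estimated at 30000 nM. The step that the limit leaves unreadable from compound 2 to compound 4 is expected to be small, resting on the unreadable step that the two limits leave unreadable from compound 1 to compound 3 and on compound 2 sitting at the limit of > 20000 nM in this assay, at which 3 of the 3 values shown sit.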

Compound 4, half-maximal effective concentration: > 20000 nM
Compound 4 was reported as a limit; the forecaster's own chance of this, stated with the estimate: 85%; the middle value does not contradict the limit.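

In this assay compound 4 gives > 20000 nM, a limit of the assay and not a number. Compound 2 gives > 20000 nM, likewise a limit. With both ends at a limit, no size can be read for the step from compound 2 to compound 4. The compounds shown leave open whether hydrogen in place of methoxycarbonyl changes the half-maximal effective concentration at all.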